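Heteroaryl exchange on the shared core

A few compounds are considered here, and "the series" means these few. Any claim that something is new, unique, unknown or untested is made for them only; others in the source may bear on it.

Compound 1 `COc1cc(-c2cn(C(=O)NCCCCc3ccccc3)c(=O)o2)ccc1F` gives 80 nM in an assay on isolated protein for inhibition of acid ceramidase (Homo sapiens), read by LC-MS, with a stated time of 1 h; a higher number here means a weaker inhibitor, a lower number a stronger inhibitor. Among the measured compounds shown here, compound 2 `O=C(NCCCCc1ccccc1)n1cc(-c2cnccn2)oc1=O` gives 32 nM in this assay, the lower of the two numbers; the step of a 2.5-fold lower number from compound 1 to compound 2 (0.40 log units; beyond the scatter) is the only measured step at this position of the shared core. Compound 3 `O=C(NCCCCc1ccccc1)n1cc(-c2nccs2)oc1=O` carries 1,3-thiazol-2-yl in place of pyrazin-2-yl on an aromatic carbon. For the measured compounds named here, only that one step bears on the new change, and it was modest, so in this assay a shift of similar size or none beyond the scatter is expected, if anything toward a higher number. Compound 3 is expected at 45 nM, between 15 nM and 130 nM, an estimated step of a 1.4-fold higher number from compound 2 to compound 3 (0.15 log units; within the scatter).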

Compound 3, half-maximal inhibitory concentration: 59 nM
For compound 3 the middle estimate is 1.3-fold (0.12 log units) below the measured one; the range from low to high includes it.
By their numbers in this assay, from the lowest: compounds 2, 3 and 1 (each within the scatter of the next, the first and the last beyond it).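

In this assay the step of a 1.8-fold higher number from compound 2 to compound 3 (0.27 log units; within the scatter) and the step of a 1.4-fold lower number from compound 1 to compound 3 (0.13 log units; within the scatter) both stay within the scatter, so at this position a five-membered aromatic ring carrying sulfur reads alongside both six-membered aryl groups. The single earlier step had shown only that compound 1 and compound 2 lie apart, and compound 3 now fills the gap between them without separating from either. Nothing available explains these numbers.

Ring size and the sulfur change together in this step, so neither can be read alone. Going by these compounds, whether an amine or a carboxylic acid on this aromatic carbon would stay in the same range remains open.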